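The source may report more compounds than this note shows. Statements on the series, on what has been measured and on what is new or still open speak of the compounds shown alone.

Measured compounds:
- compound 1, `O=C(O)c1ccccc1-c1ccc(CCc2ncc(CC3CCCC3)[nH]2)cc1`, 133 nM
- compound 2, `O=C(O)c1ccccc1-c1ccc(CCc2ncc(Cc3cccc(F)c3)[nH]2)cc1`, 159 nM
- compound 3, `O=C(O)c1ccccc1-c1ccc(CCc2ncc(Cc3ccc(F)cc3)[nH]2)cc1`, 1600 nM

In an in vitro functional assay on cells for agonist activity at Bombesin receptor subtype-3 (Homo sapiens), read by luminescence and calcium flux (on this read-out lower numbers stand for an effect already at smaller amounts and higher numbers for an effect only at larger amounts of compound), compound 3 stands at the highest number of the three. The step of a 12-fold higher number from compound 1 to compound 3 (1.08 log units; beyond the scatter) and the step of a 10-fold higher number from compound 2 to compound 3 (1.00 log units; beyond the scatter) both lie beyond the scatter, whereas a 1.2-fold higher number from compound 1 to compound 2 (0.08 log units; within the scatter) lies within it; the 4-fluorophenyl of compound 3 therefore sets it apart from both companions.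

Compound 4, `Cc1ccc(Cc2cnc(CCc3ccc(-c4ccccc4C(=O)O)cc3)[nH]2)cc1`, differs from compound 3 by methyl in place of fluoro on an aromatic carbon. Going by the values given here, no measured step exchanges fluoro for methyl on an aromatic carbon, so the measured steps bear on this change only indirectly: they show that the 4-fluorobenzyl arrangement of compound 3 is the one with the highest number, and say nothing about whether a methyl in the same place moves the number. The estimate for compound 4 is therefore a step of a 1.3-fold lower number from compound 3 to compound 4 (0.12 log units; within the scatter), expected to stay within the scatter in either direction, with a wide range. Compound 4 is expected to give about 1200 nM in this assay, between 350 nM and 4000 nM.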

Compound 4, half-maximal effective concentration: 2660 nM
Estimate against measurement, compound 4: 2.2-fold (0.35 log units) below; low and high end bracket the measured number.
By their numbers in this assay, from the lowest: compounds 1 and 2 (each within the scatter of the next); then compounds 3 and 4 (each within the scatter of the next).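

In this assay, putting methyl in place of fluoro on this aromatic carbon, para to a large group, gives a 1.7-fold higher number from compound 3 to compound 4 (0.22 log units; within the scatter), so the two groups cannot be told apart at this position. The high number of compound 3 is therefore not confined to fluoro: the 4-methylbenzyl group also stands well apart from the other two compounds, with a 17-fold higher number from compound 2 to compound 4 (1.22 log units; beyond the scatter) and a 20-fold higher number from compound 1 to compound 4 (1.30 log units; beyond the scatter), and neither of the four compounds goes against this. No evidence is available on what lies behind these numbers.

Open, from the compounds shown here alone, is whether a methoxy group, a chlorine or an amine at the same place would also keep the number this high, and whether a plain benzyl group with no substituent would fall with compound 2 or with compounds 3 and 4. Also open, going by these compounds, is how a 3-methylphenyl group would compare with the 3-fluorophenyl of compound 2.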